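Benzoyl ester of compound 1: expected cytotoxicity

The source may report more compounds than this note shows. Statements on the series, on what has been measured and on what is new or still open speak of the compounds shown alone.

Measured so far in a functional assay on Daoy cells (Homo sapiens) for cytotoxicity, read by MTT assay; on this read-out higher numbers stand for weaker inhibition and lower numbers for stronger inhibition:
- compound 1, `C=C1CC[C@@H]2CC[C@H](OC(=O)C/C(C)=C/[C@@H](O)C1)C(=O)C2(C)C`: compound 1 gives > 20 ug/mL, which is a limit of the assay and not a number.
- compound 2, `C=C1CC[C@@H]2CCC3=C(C(=O)[C@@H](/C(C)=C/C(O)C1)[C@H]3O)C2(C)C`: compound 2 gives > 20 ug/mL, again a limit of the assay rather than a number.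
- compound 3, `CC(=O)O[C@@H]1/C(C(C)C)=C\C=C(/C)CC/C=C(\C)CC[C@@H]2O[C@@]2(C)[C@H]1OC(C)=O`: compound 3 gives 16.9 ug/mL.

Where compound 1 stands: nothing more than a limit is known for it, and it sits at the limit of > 20 ug/mL in this assay, at which 2 of the 3 values shown sit. Within the data shown here, compound 3 is the only member with a numerical value, and that value lies close to the limit, so the set as a whole shows weak inhibition and no ordering among its members can be drawn.

Compound 4, `C=C1CC[C@@H]2CC[C@H](OC(=O)C/C(C)=C/[C@@H](OC(=O)c3ccccc3)C1)C(=O)C2(C)C`, differs from compound 1 by benzoyl in place of hydrogen on an oxygen on a saturated carbon. Among the measured compounds shown here, no measured pair in the set changes in one place, so there is no step to lean on; the expectation rests on compound 1 alone. The step is expected to be an at least 1.4-fold lower number from compound 1 to compound 4 (0.15 log units; that floor lies within the scatter), toward stronger inhibition but modest, with a real chance that compound 4 also returns only a limit. Compound 4 is therefore estimated at 14 ug/mL, with a range from 4 ug/mL to 40 ug/mL.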

Compound 4, half-maximal inhibitory concentration: > 20 ug/mL
Compound 4: no number, only a limit (the forecaster's own chance of this, stated with the estimate: 45%); at least 1.4-fold (0.15 log units) between middle value and limit.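

In this assay compound 1 and compound 4 each return only a limit of the assay, so no step can be read for benzoyl in place of hydrogen on an oxygen on a saturated carbon: the limit of > 20 ug/mL in this assay, at which 3 of the 4 values shown sit. The compounds shown leave open whether hydroxy to benzoyloxy changes cytotoxicity at all, and in which direction.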